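The source may report more compounds than this note shows. Statements on the series, on what has been measured and on what is new or still open speak of the compounds shown alone.

Three ureas built on one shared core have been measured in a functional assay (aorta) for inhibition, with Rattus norvegicus as the target; a lower number here means a stronger inhibitor, a higher number a weaker inhibitor. Compound 1 `CC(C)(C)c1ccc(C#N)cc1NC(=O)Nc1cccnc1` gives 25700000 nM, compound 2 `CC(C)(C)c1ccc(C#N)cc1NC(=O)Nc1ccccn1` gives 25700000 nM, and compound 3 `CC(C)(C)c1ccc(C#N)cc1NC(=O)Nc1cncnc1` gives 12400000 nM. Compound 3 thus stands at the lowest number of the three: the step of a 2.1-fold lower number from compound 1 to compound 3 (0.32 log units; beyond the scatter) and the step of a 2.1-fold lower number from compound 2 to compound 3 (0.32 log units; beyond the scatter) are both modest yet beyond the scatter, whereas no change at the digits printed from compound 1 to compound 2 (within the scatter) shows none. Compound 4 `CC(C)(C)c1ccc(C#N)cc1NC(=O)Nc1ccc(Cl)nc1` has not yet been measured in this assay. It differs from compound 3 in one place: 6-chloropyridin-3-yl in place of pyrimidin-5-yl on an amide-type nitrogen. Going by the values given here, no measured step introduces a chlorine, so that part of the change has no direct guide. The nearest guide is that compound 1 carries a pyridin-3-yl where compound 3 carries a pyrimidin-5-yl, and the step of a 2.1-fold lower number from compound 1 to compound 3 (0.32 log units; beyond the scatter) lowered the number. Since compound 4 returns to a pyridin-3-yl, a somewhat higher number than for compound 3 is expected, with wide uncertainty. Compound 4 is therefore estimated at 20000000 nM, between 6000000 nM and 60000000 nM. The expected step of a 1.6-fold higher number from compound 3 to compound 4 (0.21 log units; within the scatter) is small.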

Compound 4, half-maximal inhibitory concentration: 1600000 nM
Compound 4: middle estimate off by 13-fold (1.10 log units), on the high side; the measured number lies below the stated range.
By their numbers in this assay, from the lowest: compound 4; then compound 3; then compounds 1 and 2 (each within the scatter of the next).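

Going by these compounds alone, at this place on the amide-type nitrogen, the earlier compounds only exchanged one unsubstituted aromatic group for another, whereas chloro in place of hydrogen on an aromatic carbon brings a 16-fold lower number from compound 1 to compound 4 (1.21 log units; beyond the scatter) in this assay and counts as a large step. The 6-chloropyridin-3-yl group also gives a 16-fold lower number from compound 2 to compound 4 (1.21 log units; beyond the scatter) and a 7.8-fold lower number from compound 3 to compound 4 (0.89 log units; beyond the scatter), so among these four compounds the chlorine-bearing group moves the number further than any exchange among the unsubstituted groups. No evidence is available that would explain this step.

As far as these compounds go, whether the step belongs to chlorine itself or would also follow with a fluoro, methyl or methoxy group in its stead remains open. Also open, from the compounds shown here alone, is whether a chloro group on the pyrimidin-5-yl or pyridin-2-yl group would lower the number to a similar extent.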